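The source may hold more compounds than are shown below. What is called first, only, known or untested is meant among the compounds shown, and "the series" means these compounds.

Compound 3, `Clc1ccc(NCCNc2ccnc3cc(Cl)ccc23)cc1`, carries a chloro group on its aniline ring and is the starting point here. In a toxicity assay on Huh-7 cells (Homo sapiens) for cytotoxicity, read by MTT assay, with a stated time of 72 h (a lower number here means that less compound is tolerated, a higher number that more compound is tolerated), compound 3 gives > 100 ug/mL, which is a limit of the assay and not a measured number. Its two companions share the same core. Compound 1, `Clc1ccc2c(NCCNc3ccc(Br)cc3)ccnc2c1`, gives > 100 ug/mL in this assay, again a limit. Compound 2, `Fc1ccc(NCCNc2ccnc3cc(Cl)ccc23)cc1`, gives > 100 ug/mL in this assay, also a limit. The three exchanges among them are therefore all unreadable: a step that the two limits leave unreadable from compound 1 to compound 2, a step that the two limits leave unreadable from compound 1 to compound 3 and a step that the two limits leave unreadable from compound 2 to compound 3. What these three compounds do show together is the limit of > 100 ug/mL in this assay, at which 3 of the 3 values shown sit, so a halogen swap at this position has not yet pushed any compound into the readable range.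

The new compound 4, `N#Cc1ccc(NCCNc2ccnc3cc(Cl)ccc23)cc1`, differs from compound 3 by cyano in place of chloro on an aromatic carbon. For the measured compounds named here, no measured step involves a cyano group, so the expectation for compound 4 rests on the three limits alone. Compound 4 is estimated to sit at about 150 ug/mL, with a range from 60 ug/mL to 400 ug/mL, and the step that the limit leaves unreadable from compound 3 to compound 4 is expected to be no more than scatter, with the result most likely reported as a limit once more.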

Compound 4, half-maximal cytotoxic concentration: 39.6 ug/mL
Beside the measured number, compound 4's estimate is 3.8-fold (0.58 log units) above it; measured number below the stated range.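

In this assay, for the compounds shown here, the change to cyano gives the first readable number at this position, with an at least 2.5-fold lower number from compound 3 to compound 4 (0.40 log units; beyond the scatter), and likewise an at least 2.5-fold lower number from compound 2 to compound 4 (0.40 log units; beyond the scatter) and an at least 2.5-fold lower number from compound 1 to compound 4 (0.40 log units; beyond the scatter). These sizes are only minimum values, as the three halogen compounds all stand at a limit of the assay, and the steps among those three remain unreadable. The position can therefore move the number in this assay, although the three halogens shown leave it at the limit, and compound 4 alone stands apart: the limit of > 100 ug/mL in this assay, at which 3 of the 4 values shown sit.

On these data alone, the true size of the cyano step remains open, as does any order among the three halogen compounds. Also open, as far as these compounds go, is whether an amine or a carboxylic acid at this position, or a longer chain in the linker, would lower the number too.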